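Adding a trifluoromethyl group to compound 3

The source may report more compounds than this note shows. Statements on the series, on what has been measured and on what is new or still open speak of the compounds shown alone.

Values in a functional assay on MDA-MB-231 cells (Homo sapiens) for antiproliferative activity, read by MTT assay, with a stated time of 72 h; a lower number here means a stronger inhibitor, a higher number a weaker inhibitor:
- compound 1 `CC1=CC[C@H]2[C@H](CC[C@]2(C)O)C(C)(C)[C@@H]1CC[C@H]1[C@]2(C)CC[C@H](OC(=O)NS(=O)(=O)c3ccc(C)cc3)C(C)(C)O[C@H]2CC[C@@]1(C)O`: 47100 nM
- compound 2 `CC1=CC[C@H]2[C@H](CC[C@]2(C)O)C(C)(C)[C@@H]1CC[C@H]1[C@]2(C)CC[C@H](OC(=O)c3ccc(Cl)c(Cl)c3)C(C)(C)O[C@H]2CC[C@@]1(C)O`: 8100 nM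
- compound 3 `CC1=CC[C@H]2[C@H](CC[C@]2(C)O)C(C)(C)[C@@H]1CC[C@H]1[C@]2(C)CC[C@H](OC(=O)c3ccccc3F)C(C)(C)O[C@H]2CC[C@@]1(C)O`: 28700 nM

On these numbers, a 1.6-fold lower number from compound 1 to compound 3 (0.22 log units; within the scatter) leaves no real gap, whereas a 3.5-fold higher number from compound 2 to compound 3 (0.55 log units; beyond the scatter) is a real, modest one. So compound 3 stands level with compound 1 and weaker than compound 2.

Compound 4 `CC1=CC[C@H]2[C@H](CC[C@]2(C)O)C(C)(C)[C@@H]1CC[C@H]1[C@]2(C)CC[C@H](OC(=O)c3ccc(C(F)(F)F)cc3F)C(C)(C)O[C@H]2CC[C@@]1(C)O` keeps the shared core and makes one change: trifluoromethyl in place of hydrogen on an aromatic carbon. Trifluoromethyl replaces hydrogen on an aromatic carbon, turning 2-fluorophenyl into 2-fluoro-4-(trifluoromethyl)phenyl. Among the compounds with values here, no measured step makes this exact change. The nearest guide is compound 2 at 8100 nM, whose ring also carries more than one group. A modest drop in this assay is therefore expected, an estimated 2.2-fold lower number from compound 3 to compound 4 (0.34 log units; beyond the scatter). For compound 4 the expected value is 13000 nM, with an estimated range of 5500 nM to 30000 nM.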

Compound 4, half-maximal inhibitory concentration: 36300 nM
The estimate for compound 4 lay 2.8-fold (0.45 log units) below the measured number, and the stated range ends below it.
By their numbers in this assay, from the lowest: compound 2; then compounds 3, 4 and 1 (each within the scatter of the next).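

In this assay, trifluoromethyl on this aromatic carbon of the 2-fluorophenyl ring brings no real change (a 1.3-fold higher number from compound 3 to compound 4 (0.10 log units; within the scatter)), so this second ring group does not match the stronger result of 3,4-dichlorophenyl. The ranking therefore stays as it was: there is no real gap on one side (a 1.3-fold lower number from compound 1 to compound 4 (0.11 log units; within the scatter)), but a real, modest gap remains on the other (a 4.5-fold higher number from compound 2 to compound 4 (0.65 log units; beyond the scatter)). No evidence is available to explain these results. Going by these compounds, it remains open whether a methoxy group or an amine on the same carbon would behave differently, and what trifluoromethyl does on a ring without the fluoro group.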